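This account rests on a few compounds, and the source may have more. Where it says the series, first, only, none or still open, it means among the compounds named here.

Compound 1 `Cn1c(CN2CCC(c3ccccc3C(F)(F)F)CC2)nc2ccccc21`, compound 2 `Cn1c(CN2CCN(c3ccccc3F)CC2)nc2ccccc21` and compound 3 `Cn1c(CN2CCN(c3ccccc3C(F)(F)F)CC2)nc2ccccc21` share a common core and differ in the group carried on the aromatic ring of carbon only and in the ring that links it to that core. In an assay on CHO cells with metabotropic glutamate receptor 2 (Homo sapiens) as the target, read by FLIPR (on this read-out higher numbers stand for larger maximal responses and lower numbers for smaller maximal responses), compound 1 gives 94%. In this assay compound 3 gives 84%, and compound 2 gives 64% in this assay. The difference between the core of compound 1 and the core of compound 3 is not broken down here. The numbers for compound 1 and compound 3 lie within the scatter of each other, while the number for compound 2 lies beyond it.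

Between compound 3 and compound 2 the change is fluoro in place of trifluoromethyl on an aromatic carbon, and it brings a number 20 percentage points lower from compound 3 to compound 2 (beyond the scatter).

Compound 4 `Cn1c(CN2CCC(c3ccccc3F)CC2)nc2ccccc21` has not yet been tested in this assay. It stands to compound 1 as compound 2 stands to compound 3: the change is fluoro in place of trifluoromethyl on an aromatic carbon, the same change made on a different core. For the measured compounds named here, the expectation for compound 4 rests on that earlier step, because a number 20 percentage points lower from compound 3 to compound 2 (beyond the scatter) is the only measured example of this change. The step from compound 1 to compound 4 in this assay is therefore expected to be a number 20 percentage points lower from compound 1 to compound 4 (beyond the scatter). For compound 4 the estimated value in this assay is 74%, with an expected range from 58% to 90%.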

Compound 4, largest response reached (Emax), in percent of the reference or control that the assay uses: 91%
The estimate for compound 4 lay 17 percentage points below the measured number; measured number outside the range, above it.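

In this assay, fluoro in place of trifluoromethyl on an aromatic carbon brings a number 3 percentage points lower from compound 1 to compound 4 (within the scatter). Set beside the earlier example, the change did not carry from one core to the other with the same size: the same change on two cores in this assay, a number 20 percentage points lower (beyond the scatter) from compound 3 to compound 2 and a number 3 percentage points lower (within the scatter) from compound 1 to compound 4, 17 percentage points apart, beyond the scatter of two such steps. For the compounds shown here, these two pairs show that, in this series, the size of the step depends on the core that carries it, but they do not show which feature of the cores sets that size, and with only two examples they cannot say what the step would be on any further core.

The compounds shown carry only trifluoromethyl or fluoro on the six-membered aromatic ring of carbon only, so it remains open how a chloro, methoxy or nitrile group in that place would read in this assay, and whether either of those groups would also depend on the core. From the compounds shown here alone, it also remains open whether the difference between the two cores would persist with a plain hydrogen on that aromatic carbon, or with a hydroxyl group or an amine added to the ring that links the aromatic ring to the core.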